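This account rests on a few compounds, and the source may have more. Where it says the series, first, only, none or still open, it means among the compounds named here.

Three amides sharing one core carry different aryl groups on the triazole nitrogen. Compound 1 `Cc1ccc(-n2cc(CNC(=O)c3cccc4c3cnn4C(C)C)nn2)cc1C` gives 23400 nM in a functional assay on PC-3 cells (Homo sapiens) for inhibition, read by MTT assay, with a stated time of 72 h; on this read-out lower numbers stand for stronger inhibition and higher numbers for weaker inhibition. Compound 2 `CC(C)n1ncc2c(C(=O)NCc3cn(-c4ccc(F)cc4)nn3)cccc21` reaches only the limit of this assay, > 40000 nM, which is a limit and not a number (the limit of > 40000 nM in this assay, at which 1 of the 3 values shown sits). Compound 3 `CC(C)n1ncc2c(C(=O)NCc3cn(-c4cccc(F)c4)nn3)cccc21` gives 36100 nM in this assay. Among the two numbers shown, compound 3 stands with the higher one, but the step of a 1.5-fold higher number from compound 1 to compound 3 (0.19 log units; within the scatter) lies within the scatter, and the step of an at least 1.1-fold lower number from compound 2 to compound 3 (0.04 log units; that floor lies within the scatter) rests on a limit. The step of an at least 1.7-fold higher number from compound 1 to compound 2 (0.23 log units; that floor lies within the scatter) likewise stays within the scatter at its floor. The unmeasured compound 4 `CC(C)n1ncc2c(C(=O)NCc3cn(-c4ccccc4F)nn3)cccc21` differs from compound 3 only by 2-fluorophenyl in place of 3-fluorophenyl on an aromatic nitrogen. Every aryl exchange measured so far has moved this assay by less than the scatter, so the same holds for this one: the expected step of a 1.0-fold lower number from compound 3 to compound 4 (0.01 log units; within the scatter) is none beyond the scatter. Compound 4 is therefore estimated at 35000 nM, with a range from 15000 nM to 80000 nM, and a fair chance that this assay reports only a limit.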

Compound 4, half-maximal inhibitory concentration: > 40000 nM
Compound 4 was reported as a limit; the forecaster's own chance of this, stated with the estimate: 35%; at least 1.1-fold (0.05 log units) between middle value and limit.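

With 2-fluorophenyl on the aromatic nitrogen, all three fluorophenyl placements have now been seen, and in this assay compound 4 gives > 40000 nM, a limit and not a number, which it shares with compound 2: the limit of > 40000 nM in this assay, at which 2 of the 4 values shown sit.

The exchange of 3-fluorophenyl for 2-fluorophenyl reads as an at least 1.1-fold higher number from compound 3 to compound 4 (0.04 log units; that floor lies within the scatter), and the exchange of 3,4-dimethylphenyl for 2-fluorophenyl reads as an at least 1.7-fold higher number from compound 1 to compound 4 (0.23 log units; that floor lies within the scatter), so neither floor shows a real difference. Among these compounds, the step between compound 2 and compound 4 cannot be read, and so the shifted fluorine places no fluorophenyl compound apart from another.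

Still open, from the compounds shown here alone, is whether any other group at this position, such as an aminophenyl, a carboxyphenyl or a benzyl, would move the read-out beyond the scatter. Also open, going by these compounds, is how far compound 2 and compound 4 lie past their limit.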